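A few compounds are considered here, and "the series" means these few. Any claim that something is new, unique, unknown or untested is made for them only; others in the source may bear on it.

In a functional assay on L1210 cells (Mus musculus), with a stated time of 48 h (a lower number here means a stronger inhibitor, a higher number a weaker inhibitor), compound 1 `CCCCC(Nc1cc(NC(=O)OCC)nc(N)c1[N+](=O)[O-])C(C)=O` gives 31000 nM and compound 2 `CCCCC(O)C(C)Nc1cc(NC(=O)OCC)nc(N)c1[N+](=O)[O-]` gives 55000 nM. For the measured compounds named here, these are the only two numbers available, and they lie within the scatter of each other, so compound 2 stands level with compound 1. Compound 3 `CCCCC(Nc1cc(NC(=O)OCC)nc(N)c1[N+](=O)[O-])C(C)O` has the same atoms as compound 2, joined differently: 1-(1-hydroxyethyl)pentyl in place of 2-hydroxy-1-methylhexyl on a nitrogen on an aromatic ring. It carries 1-(1-hydroxyethyl)pentyl in place of 2-hydroxy-1-methylhexyl on a nitrogen on an aromatic ring. Going by the values given here, only one measured step bears on this change, also made on that nitrogen: a 1.8-fold higher number from compound 1 to compound 2 (0.25 log units; within the scatter). That single step stayed within the scatter, so no shift beyond the scatter is expected in this assay, and no direction can be assigned with confidence. The expected step is a 1.2-fold lower number from compound 2 to compound 3 (0.09 log units; within the scatter). For compound 3 the estimated value is 45000 nM, with an expected range of 20000 nM to 100000 nM.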

Compound 3, half-maximal inhibitory concentration: 56000 nM
For compound 3 the middle estimate is 1.2-fold (0.09 log units) below the measured one; the range from low to high includes it.
By their numbers in this assay, from the lowest: compounds 1, 2 and 3 (each within the scatter of the next).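

In this assay, the two arrangements of the same atoms on the nitrogen, 2-hydroxy-1-methylhexyl and 1-(1-hydroxyethyl)pentyl, cannot be told apart, with a 1.0-fold higher number from compound 2 to compound 3 (0.01 log units; within the scatter). The result also adds a direct exchange on the saturated chain carbon bound to that nitrogen, 1-hydroxyethyl in place of acetyl, and this gives a 1.8-fold higher number from compound 1 to compound 3 (0.26 log units; within the scatter), so the hydroxyl and carbonyl forms of this side chain stand level in this assay, as do the two hydroxyl isomers. Nothing available explains why these side chains stand level.

On these data alone, it remains open whether an amine or a carboxylic acid on this chain would give a step beyond the scatter. The same question stands for a longer chain in place of the pentyl part.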